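The source may hold more compounds than are shown below. What is called first, only, known or untested is meant among the compounds shown, and "the series" means these compounds.

Compound 3 `O=C(CCN1CCC(CCCn2c(COc3ccccc3)nc3c(OCCCN4CCCCC4)cccc32)CC1)c1ccccc1` gives the lowest of the three numbers in an in vitro assay on AV12 cells for binding affinity to Neuropeptide Y receptor type 1 (Homo sapiens) (on this read-out higher numbers stand for weaker inhibition and lower numbers for stronger inhibition), at 0.112 nM. Its nearest neighbour is compound 1 `C=CCCN1CCC(CCCn2c(COc3ccccc3)nc3c(OCCCN4CCCCC4)cccc32)CC1`, which in this assay gives 0.707 nM, and the furthest is compound 2 `c1ccc(OCc2nc3c(OCCCN4CCCCC4)cccc3n2CCCC2CCNCC2)cc1`, which in this assay gives 4.5 nM. The step of a 6.3-fold lower number from compound 1 to compound 3 (0.80 log units; beyond the scatter) was modest, and the step of a 40-fold lower number from compound 2 to compound 3 (1.60 log units; beyond the scatter) was large.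

Compound 4 `C(=C\c1ccccc1)\CN1CCC(CCCn2c(COc3ccccc3)nc3c(OCCCN4CCCCC4)cccc32)CC1` has not yet been measured. It differs from compound 3 in one place: 2-phenylethenyl in place of benzoylmethyl on a saturated chain carbon bound to an amine nitrogen in a ring. Both steps that reach compound 3 bear on this change. The step of a 40-fold lower number from compound 2 to compound 3 (1.60 log units; beyond the scatter) shows that the whole 2-benzoylethyl group matters a great deal, while the step of a 6.3-fold lower number from compound 1 to compound 3 (0.80 log units; beyond the scatter) shows that the benzoyl part alone accounts for a modest share of it. Compound 4 keeps the six-membered aromatic ring but loses the one hydrogen-bond acceptor, so a modest step back toward the number of compound 1 is expected, giving a 2.7-fold higher number from compound 3 to compound 4 (0.43 log units; beyond the scatter). The estimate for compound 4 in this assay is 0.3 nM, with a range from 0.1 nM to 0.9 nM.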

Compound 4, inhibition constant: 0.183 nM
Compound 4: the middle estimate sits 1.6-fold (0.21 log units) above what was measured; low and high end bracket the measured number.
By their numbers in this assay, from the lowest: compounds 3 and 4 (each within the scatter of the next); then compound 1; then compound 2.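

Replacing benzoylmethyl with 2-phenylethenyl removes the hydrogen-bond acceptor counted in the group, yet this assay shows a 1.6-fold higher number from compound 3 to compound 4 (0.21 log units; within the scatter), so the compounds shown give no sign that this acceptor is needed at this position. The large gain over the free ring amine remains without it, at a 25-fold lower number from compound 2 to compound 4 (1.39 log units; beyond the scatter), and the advantage over the small alkenyl substituent remains too, at a 3.9-fold lower number from compound 1 to compound 4 (0.59 log units; beyond the scatter). Both compounds that carry a six-membered aromatic ring in this substituent, compound 3 and compound 4, therefore lie beyond the scatter from compound 1 and compound 2, with or without the carbonyl.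

No separate measurement explains these numbers. Going by these compounds, whether the aromatic ring itself is what counts stays open: a cyclohexyl ring, a pyridine ring or a longer chain in the same place would bear on that.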